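The source may report more compounds than this note shows. Statements on the series, on what has been measured and on what is new or still open speak of the compounds shown alone.

Compound 3 `O=C1/C(=C/c2ccccc2)CCC/C1=C\c1ccc(Cl)cc1` gives 27.6% in an assay on isolated protein for inhibition of Alpha glucosidase (Homo sapiens), with stated times of 5 min and 15 min, tested at 50 uM (on this read-out higher numbers stand for more inhibition at the one concentration tested (going by the name of the read-out) and lower numbers for less inhibition), the lowest of the three numbers in hand. Compound 1 `O=C1/C(=C/c2ccccc2)CCC/C1=C\c1ccccc1Cl` gives 43% and compound 2 `O=C1/C(=C/c2ccccc2)CCC/C1=C\c1cccc(O)c1` gives 65.1%; the steps between them are a number 15.4 percentage points lower from compound 1 to compound 3 (beyond the scatter), a number 37.5 percentage points lower from compound 2 to compound 3 (beyond the scatter) and a number 22.1 percentage points higher from compound 1 to compound 2 (beyond the scatter). Each of these exchanges the whole aryl group on the double-bonded chain carbon; none exchanges one halogen for another on the same aromatic carbon. Compound 4 `O=C1/C(=C/c2ccccc2)CCC/C1=C\c1ccc(F)cc1` differs from compound 3 by fluoro in place of chloro on an aromatic carbon. Going by the values given here, no measured step bears directly on this exchange, so no step beyond the scatter is expected in this assay. Compound 4 is expected to give about 30%, within 15% to 48%, a step of a number 2.4 percentage points higher from compound 3 to compound 4 (within the scatter) expected.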

Compound 4, a percentage reported as inhibition, at one concentration (the size of the read-out at that concentration, not a potency): 34%
Compound 4: middle estimate off by 4 percentage points, on the low side; low and high end bracket the measured number.
By their numbers in this assay, from the lowest: compounds 3, 4 and 1 (each within the scatter of the next, the first and the last beyond it); then compound 2.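

In this assay the exchange of chloro for fluoro on an aromatic carbon, para to a large group, is a number 6.4 percentage points higher from compound 3 to compound 4 (within the scatter) and so does not separate the two halogens at this position. With a number 9 percentage points lower from compound 1 to compound 4 (within the scatter) and a number 31.1 percentage points lower from compound 2 to compound 4 (beyond the scatter) the 4-fluorophenyl group does not separate from the 2-chlorophenyl group but stays well apart from the 3-hydroxyphenyl group. No evidence at hand accounts for these steps.

Open, on these data alone, is whether the higher number of compound 2 belongs to the hydroxy group itself or to where it sits on the ring, and how an amine or a carboxylic acid on that ring would read.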